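The source may report more compounds than this note shows. Statements on the series, on what has been measured and on what is new or still open speak of the compounds shown alone.

Working notes on the series. In a functional assay on K562 cells (Homo sapiens) for cytotoxicity, in the presence of a further agent that is not named here (a lower number here means a stronger inhibitor, a higher number a weaker inhibitor), compound 1 (`Clc1ccc(-c2cc(-c3ccsc3)nc(-c3ccco3)c2)o1`) gives 22400 nM and compound 2 (`Clc1ccc(-c2cc(-c3cccnc3)nc(-c3cccs3)c2)o1`) gives 22300 nM so these two stand level within the scatter. Compound 3 (`Cc1ccc(-c2cc(-c3ccoc3)cc(-c3ccsc3)n2)cc1`) gives 47800 nM as a higher number than compound 1 shows, and that gap lies beyond the scatter. Compound 1 therefore sits with compound 2 on the stronger side of this small set, with compound 3 as the weaker inhibitor.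

Among the measured compounds shown here, no two measured compounds differ in one place only, so the data hold no direct measure of what a single change does. Compound 4 (`Cc1ccc(-c2cc(-c3ccc(Cl)o3)cc(-c3ccsc3)n2)o1`) has not yet been measured. Its difference from compound 1 is methyl in place of hydrogen on an aromatic carbon and turns furan-2-yl into 5-methylfuran-2-yl, with methyl in place of hydrogen on an aromatic carbon.

For the measured compounds named here, the only guide is the narrow spread so far, with compound 1 at 22400 nM and compound 3 at 47800 nM across differing substituents. No step beyond the scatter is expected in this assay in either direction. The estimated move (a 1.1-fold higher number from compound 1 to compound 4 (0.05 log units; within the scatter)) is expected to be small. In this assay the estimate for compound 4 is 25000 nM with an expected range from 10000 nM to 60000 nM as its ends.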

Compound 4, half-maximal inhibitory concentration: 23300 nM
Compound 4: middle estimate off by 1.1-fold (0.03 log units), on the high side; measured number inside the range.
By their numbers in this assay, from the lowest: compounds 2, 1 and 4 (each within the scatter of the next); then compound 3.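

In this assay, the series now has its first comparison in one place only: a 1.0-fold higher number from compound 1 to compound 4 (0.02 log units; within the scatter), for furan-2-yl to 5-methylfuran-2-yl. The earlier compounds shown here differed in several places at once and could show only a narrow spread, whereas this step shows that methyl in place of hydrogen, on an aromatic carbon next to the ring oxygen and two ring bonds from the ring atom that bears a large group, leaves the number within the scatter. No measurement in hand bears on why this position takes the methyl with no step beyond the scatter.

On these data alone, this is one change at one position, so it remains open whether a group other than methyl at the same carbon, such as an amine, a carboxylic acid or a longer chain like n-butyl, would also leave the number level. As far as these compounds go, it is equally open whether methyl in place of hydrogen would give a step this small on the other rings of compound 1, where no single-place comparison is yet available.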